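Methoxy for methyl on the pendant ring of compound 3

A few compounds are considered here, and "the series" means these few. Any claim that something is new, unique, unknown or untested is made for them only; others in the source may bear on it.

Measured compounds:
compound 1 `N=C(NCCCc1c[nH]cn1)NCCCC(c1ccccc1)c1ccccn1`, 6.61
compound 2 `N=C(NCCCc1c[nH]cn1)NCCC(c1ccccc1)c1ccccn1`, 7.39
compound 3 `Cc1ccc(C(CC/N=C(\N)NCCCc2c[nH]cn2)c2ccccn2)cc1`, 7.71

In a functional assay on cardiac atrium for agonist activity at histamine H2 receptor (Cavia porcellus) (on this read-out lower numbers stand for lower potency and higher numbers for higher potency (the scale is a negative logarithm)), compound 3 gives the highest of the three numbers. Compound 2 stands nearest to it, with a number lower by a margin beyond the scatter, and compound 1 stands furthest, also beyond the scatter. Going by the values given here, all three share the same guanidine-linked core and differ only in the chain length and in the substituent on the phenyl ring, and no single-change step between the measured pairs is given, so only the bare values can be compared.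

Compound 4 `COc1ccc(C(CC/N=C(\N)NCCCc2c[nH]cn2)c2ccccn2)cc1` is the next compound in this series. It differs from compound 3 as follows: methoxy in place of methyl on an aromatic carbon. The group that leaves and the group that enters are of similar size, and the entering group brings one hydrogen-bond acceptor. Among the compounds with values here, nothing among the measured compounds shows how this position responds, so the expectation is for no step beyond the scatter in this assay, with a wide range to either side; the expected step is a number 0.11 log units lower from compound 3 to compound 4 (within the scatter). Compound 4 is therefore estimated at 7.6, within a range from 7 to 8.2.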

Compound 4, negative logarithm of the half-maximal effective concentration: 7.44
Compound 4: middle estimate off by 0.16 log units, on the high side, and the stated range covers the measured number.
By their numbers in this assay, from the lowest: compound 1; then compounds 2, 4 and 3 (each within the scatter of the next, the first and the last beyond it).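

In this assay, the change from 4-methylphenyl to 4-methoxyphenyl gives a number 0.27 log units lower from compound 3 to compound 4 (within the scatter), so at this position the methoxy group, with its added oxygen and hydrogen-bond acceptor, brings no step beyond the scatter. Going by these compounds alone, this is the first step read at this position, as the earlier compounds showed no single change there and offered only their bare values. Nothing measured here bears on why the step stays this small.

On these data alone, whether a hydroxyl group, a chlorine atom or a dimethylamino group would be taken up as readily in this position remains open, as does whether a carboxylic acid there would bring a step beyond the scatter. Also open, as far as these compounds go, is whether the same exchange of methyl for methoxy would give a similar step on the longer chain of compound 1.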